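Fluoro in place of methoxy: one small change

A few compounds are considered here, and "the series" means these few. Any claim that something is new, unique, unknown or untested is made for them only; others in the source may bear on it.

- compound 1 `Cc1cc(C)c(S(=O)(=O)N2CCN(C3CN4CCC3CC4)CC2)c(C)c1`: 84 nM
- compound 2 `COc1ccccc1-c1cccc(S(=O)(=O)N2CCC(N3CCC(C)CC3)CC2)c1`: 21 nM
- compound 3 `Cc1cc(C)c(S(=O)(=O)N2CCC(N3CCC(CCO)CC3)CC2)c(C)c1`: 19 nM

These numbers come from a functional assay on DLD-1 cells (Homo sapiens) for antiproliferative activity, read by CellTiter-Glo, with a stated time of 72 h; on this read-out lower numbers stand for stronger inhibition and higher numbers for weaker inhibition. There, compound 2 gives 21 nM, within the usual scatter of compound 3 at 19 nM, while compound 1 at 84 nM has a higher number, beyond the scatter.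

Compound 4 `CC1CCN(C2CCN(S(=O)(=O)c3cccc(-c4ccccc4F)c3)CC2)CC1` keeps compound 2 intact except for one group, ortho to a large group: 2-methoxyphenyl becomes 2-fluorophenyl (fluoro in place of methoxy on an aromatic carbon).

Among the measured compounds shown here, no two measured compounds differ in one place, so the data hold no direct precedent for this swap. The expected change is a 1.4-fold higher number from compound 2 to compound 4 (0.15 log units; within the scatter), with no step beyond the scatter. Compound 4 is estimated at 30 nM, with an expected range from 10 nM to 90 nM.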

Compound 4, half-maximal inhibitory concentration: 10 nM
Beside the measured number, compound 4's estimate is 3.0-fold (0.48 log units) above it; low and high end bracket the measured number.
By their numbers in this assay, from the lowest: compounds 4, 3 and 2 (each within the scatter of the next, the first and the last beyond it); then compound 1.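

Among the compounds shown here, on an aromatic carbon ortho to a large group, fluoro in place of methoxy gives a 2.1-fold lower number from compound 2 to compound 4 (0.32 log units; beyond the scatter) in this assay and provides the first comparison of compounds differing in one place. The methoxy is therefore not required at this position for activity in these cells, as the smaller fluoro retains it and gains modestly. No measurement at hand offers a reason for this step.

As far as these compounds go, it remains open how a plain hydrogen, chloro, methyl or nitrile would compare at this position. From the compounds shown here alone, whether the same swap would give a similar step on another core also remains open.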